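A Sulfate Chain With a Double Bond: Expected Cytotoxicity

A few compounds are considered here, and "the series" means these few. Any claim that something is new, unique, unknown or untested is made for them only; others in the source may bear on it.

Compound 1 `CC(C)CCC[C@@H](C)COS(=O)(=O)O` gives 20.9 ug/mL
Compound 2 `CC(C)CCCCCOS(=O)(=O)O` gives 15 ug/mL

Among the measured compounds shown here, both numbers come from a functional assay on WEHI-164 cells (Mus musculus) for cytotoxicity, read by MTT assay, with a stated time of 96 h (a higher number here means a weaker inhibitor, a lower number a stronger inhibitor), and the only step measured so far is a 1.4-fold lower number from compound 1 to compound 2 (0.14 log units; within the scatter). Compound 2 has the lower of the two numbers shown, but its gap to compound 1 lies within the scatter. Compound 3 `CC/C=C\CCCCOS(=O)(=O)O` differs from compound 2 by but-1-en-1-yl in place of isobutyl on a saturated chain carbon, four bonds along the chain from an oxygen on an unsaturated carbon. For the measured compounds named here, the one measured step concerns a methyl on the chain and says nothing about a double bond, so no step bears on this change, and the expected shift is no change at the digits printed from compound 2 to compound 3 (within the scatter), none beyond the scatter. Compound 3 is therefore estimated at 15 ug/mL, expected between 7 ug/mL and 32 ug/mL.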

Compound 3, half-maximal inhibitory concentration: 12.2 ug/mL
For compound 3 the middle estimate is 1.2-fold (0.09 log units) above the measured one, and the stated range covers the measured number.
By their numbers in this assay, from the lowest: compounds 3, 2 and 1 (each within the scatter of the next).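

In this assay putting but-1-en-1-yl in place of isobutyl gives a 1.2-fold lower number from compound 2 to compound 3 (0.09 log units; within the scatter) and so adds a first piece of information: at this place on the chain, a double bond can enter and the isobutyl end can leave with no shift that can be told from the scatter. No outside measurement bears on this result, so it stands without an explanation.

Still open, from the compounds shown here alone, is how a longer chain at this place would read. So is whether a carboxylic acid could stand in for the sulfate.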